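A few compounds are considered here, and "the series" means these few. Any claim that something is new, unique, unknown or untested is made for them only; others in the source may bear on it.

Compound 1, `Cc1ccc([C@@H]2[C@@H](C(=O)Nc3ccc(F)c(C#N)c3)c3ccccc3C(=O)N2CC(C)C)s1`, is the starting point, and it is measured in a physicochemical assay for solubility, in phosphate buffer, with a stated time of 18 h, at pH 7; on this read-out higher numbers stand for higher solubility and lower numbers for lower solubility. In this assay compound 1 gives < 1000 nM, which is a limit of the assay rather than a number. Compound 2, `CC(C)CN1C(=O)c2ccccc2[C@H](C(=O)Nc2ccc(F)c(C#N)c2)[C@H]1c1ccc(C#N)s1`, gives 4900 nM in this assay. The step between them is an at least 4.9-fold higher number from compound 1 to compound 2 (0.69 log units; beyond the scatter). Compound 3, `CC(C)CN1C(=O)c2ccccc2[C@H](C(=O)Nc2ccc(F)c(C#N)c2)[C@H]1c1cnsc1`, has not yet been measured in this assay. Compound 3 differs from compound 1 in one place: 1,2-thiazol-4-yl in place of 5-methylthiophen-2-yl on a saturated ring carbon. For the measured compounds named here, the only measured step that bears on this change is the one from compound 1 to compound 2, where a cyano in place of methyl on an aromatic carbon gave an at least modest rise; that step changed the same five-membered aromatic ring that is exchanged here, and the change to compound 3 removes the methyl as well as replacing the ring. Because compound 1 sits at the limit of < 1000 nM in this assay, at which 1 of the 2 values shown sits, the true size of any rise can only be read from where compound 3 lands. A rise beyond the scatter is expected in an at least 5.0-fold higher number from compound 1 to compound 3 (0.69 log units; beyond the scatter). Compound 3 is therefore expected to give about 5000 nM, between 1500 nM and 20000 nM.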

Compound 3, solubility: 20000 nM
The estimate for compound 3 lay 4.0-fold (0.60 log units) below the measured number, and the stated range covers the measured number.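

In this assay, the saturated ring carbon tolerates more than a change of substituent on the thiophene: with 1,2-thiazol-4-yl in place of 5-cyanothiophen-2-yl, the exchange of the whole ring gives a 4.1-fold higher number from compound 2 to compound 3 (0.61 log units; beyond the scatter). Against the starting compound, the exchange of 5-methylthiophen-2-yl for 1,2-thiazol-4-yl gives an at least 20-fold higher number from compound 1 to compound 3 (1.30 log units; beyond the scatter), and this size is a floor rather than a measured gap because compound 1 stands at a limit: the limit of < 1000 nM in this assay, at which 1 of the 3 values shown sits. The thiophene is therefore not needed at this position for a high number, as compound 3, with its five-membered aromatic ring with 2 hetero atoms, carries the highest number of the three compounds.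

The compounds shown do not separate the ring from its substituent, as 1,2-thiazol-4-yl differs from both thiophenes in each; a plain thiophen-2-yl or a 1,2-thiazole bearing a methyl would tell these apart. From the compounds shown here alone, how this assay responds at this position to a six-membered ring such as pyridine, or to a ring bearing an amine or a carboxylic acid, also stays open.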